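Extending the ether chain on a cyclopropylamino purine antagonist

The compounds below may be only part of what the source reports. "The series", "measured", "known", "first", "only" and "open" are said of these compounds alone.

Measured compounds:
Compound 1, `CCCn1cnc2c(NC3CC3)ncnc21`, gives 6 mg/kg in a functional assay on the whole organism for antagonist activity, with Rattus norvegicus as the target; on this read-out lower numbers stand for an effect already at smaller amounts and higher numbers for an effect only at larger amounts of compound.
Compound 2, `CCC(C)n1cnc2c(NC3CC3)ncnc21`, gives 13.5 mg/kg in this assay.
Compound 3, `CCOc1nc(NC2CC2)c2ncn(CC3CC3)c2n1`, gives 0.8 mg/kg in this assay.

Compound 1 and compound 2 differ in one place: methyl in place of hydrogen on a saturated chain carbon bound to an aromatic nitrogen and a saturated chain carbon. That change gave a 2.3-fold higher number from compound 1 to compound 2 (0.35 log units; beyond the scatter). Compound 3 has the lowest of the three numbers, and the difference between its core and the core of compound 1 is not broken down here.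

Compound 4, `CCCOc1nc(NC2CC2)c2ncn(CC3CC3)c2n1`, has not yet been tested in this assay. It differs from compound 3 by methyl in place of hydrogen on a saturated chain carbon, two bonds along the chain from an oxygen on an aromatic ring. This is the same kind of change as from compound 1 to compound 2, but at a different place: there the carbon was bound to an aromatic nitrogen and a saturated chain carbon, here it is two bonds along the chain from an oxygen on an aromatic ring. Beside the earlier step, a modest step of a 1.9-fold higher number from compound 3 to compound 4 (0.27 log units; within the scatter) is expected for compound 4, resting on the step of a 2.3-fold higher number from compound 1 to compound 2 (0.35 log units; beyond the scatter) that the same added methyl produced. Compound 4 is therefore estimated at 1.5 mg/kg, between 0.6 mg/kg and 4 mg/kg.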

Compound 4, dose for half-maximal effect: 2.5 mg/kg
Beside the measured number, compound 4's estimate is 1.7-fold (0.22 log units) below it, within the range that was stated.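

In this assay, going from ethoxy to propoxy gave a 3.1-fold higher number from compound 3 to compound 4 (0.49 log units; beyond the scatter). The earlier methyl addition on the other core points the same way, and the two steps do not differ in size beyond what repeated measurements allow: the same change on two cores in this assay, a 2.3-fold higher number (0.35 log units; beyond the scatter) from compound 1 to compound 2 and a 3.1-fold higher number (0.49 log units; beyond the scatter) from compound 3 to compound 4, 1.4-fold (0.14 log units) apart, within the scatter of two such steps. In these two pairs, then, a methyl added on a saturated chain carbon raised the number by a similar amount on both cores, but two pairs do not make a general rule, and since the methyl sits at a different place in each pair, they cannot separate the influence of the core from that of the place.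

The compounds shown leave open whether the number would keep rising with a longer chain such as butoxy, or how a shorter methoxy group or a branched isopropoxy group would compare with ethoxy. They also leave open whether the same step would hold for a chain carrying an amine or a hydroxyl group.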